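The source may hold more compounds than are shown below. What is called first, only, known or untested is meant among the compounds shown, and "the series" means these compounds.

Working notes on the series. In a functional assay on HeLa cells (Homo sapiens) for antiproliferative activity, read by sulforhodamine B assay, with a stated time of 48 h (on this read-out lower numbers stand for stronger inhibition of growth and higher numbers for weaker inhibition of growth), compound 1 `Cc1cc2c(cc1C)C(Cl)=C(c1nnc(-c3ccccc3)o1)CCC2` gives 4680 nM, compound 2 `Cc1cc2c(cc1C)C(Cl)=C(c1nnc(-c3cccc(Cl)c3)o1)CCC2` gives 5940 nM and compound 3 `Cc1cc2c(cc1C)C(Cl)=C(c1nnc(-c3cccc(I)c3)o1)CCC2` gives 4460 nM. Compound 3 thus stands level with the other two, all three lying within the scatter of one another. Next comes compound 4 `Cc1cc2c(cc1C)C(Cl)=C(c1nnc(-c3cccc(C(F)(F)F)c3)o1)CCC2`, with trifluoromethyl in place of iodo on an aromatic carbon. Three measured steps at this place bear on the change: a 1.3-fold higher number from compound 1 to compound 2 (0.10 log units; within the scatter), a 1.0-fold lower number from compound 1 to compound 3 (0.02 log units; within the scatter) and a 1.3-fold lower number from compound 2 to compound 3 (0.12 log units; within the scatter). None leaves the scatter, so no step beyond the scatter is expected in this assay. The expected step is a 1.1-fold higher number from compound 3 to compound 4 (0.03 log units; within the scatter). The estimated value for compound 4 is 4800 nM, with an expected range from 2400 nM to 9500 nM.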

Compound 4, concentration for 50% growth inhibition: 1570 nM
For compound 4 the middle estimate is 3.1-fold (0.49 log units) above the measured one, and the stated range ends above it.
By their numbers in this assay, from the lowest: compound 4; then compounds 3, 1 and 2 (each within the scatter of the next).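

In this assay this position no longer looks indifferent: trifluoromethyl gives a 2.8-fold lower number from compound 3 to compound 4 (0.45 log units; beyond the scatter) and a 3.8-fold lower number from compound 2 to compound 4 (0.58 log units; beyond the scatter) and a 3.0-fold lower number from compound 1 to compound 4 (0.47 log units; beyond the scatter) even though hydrogen, chloro and iodo stay within the scatter of one another. Among the groups shown, only trifluoromethyl moves the number beyond the scatter, and the gain remains modest. Nothing measured here accounts for this step. The compounds shown leave open whether the step is particular to trifluoromethyl or would also appear with a nitrile, a methoxy group or an amine at this place. They also leave open whether trifluoromethyl would give the same step on another carbon of this ring.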